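A few compounds are considered here, and "the series" means these few. Any claim that something is new, unique, unknown or untested is made for them only; others in the source may bear on it.

Measured compounds:
- compound 1, `C/C(=N\C#N)NCc1ccc(Cl)nc1`: 1.07
- compound 2, `CC/C(=N\C#N)N(C)Cc1ccc(Cl)nc1`: 1.12

Of the compounds shown here, two have been measured in a physicochemical assay for lipophilicity, read by HPLC, using the shake flask method; a higher number here means a more lipophilic compound, a lower number a more polar compound. Compound 1 gives 1.07, and compound 2 gives 1.12. These two values lie within the usual scatter of each other, so neither compound can be called more or less lipophilic than the other on this evidence; both sit in a moderately polar region. Compound 2 differs from compound 1 in more than one place, so no single change can be read from their pair.

The compound to be measured next is compound 3, `C=CCN(Cc1ccc(Cl)nc1)/C(C)=N/C#N`. It differs from compound 1 in one place: allyl in place of hydrogen on an amine nitrogen. Three carbon atoms with one double bond are added where a hydrogen stood before, on the nitrogen that also carries the saturated chain carbon and the carbon double-bonded to nitrogen. Going by the values given here, no measured pair shows this exact change, so the size of its effect in this assay is open. Adding carbon without adding any hydrogen-bond donor or acceptor is generally expected to move a compound toward the lipophilic end, and a step beyond the scatter is expected here.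

For compound 3 the expected value in this assay is 1.8, in the range 1.3 to 2.3, an expected step of a number 0.73 log units higher from compound 1 to compound 3 (beyond the scatter).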

Compound 3, partition coefficient: 1.56
Compound 3: middle estimate off by 0.24 log units, on the high side, within the range that was stated.
By their numbers in this assay, from the lowest: compounds 1 and 2 (each within the scatter of the next); then compound 3.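

In this assay, allyl in place of hydrogen on an amine nitrogen gives a number 0.49 log units higher from compound 1 to compound 3 (beyond the scatter). Going by these compounds alone, this is the first change in a single place that can be read, since compounds 1 and 2 differ in more than one place and their pair could not isolate any one change. It shows that this nitrogen, which also carries the saturated chain carbon and the carbon with a double bond to nitrogen, is a place where a change of substituent can move the number by more than the scatter, although nothing measured here explains the size of this step.

Going by these compounds, what remains open is whether the double bond of the allyl group matters to the size of the step, which a saturated propyl chain on the same nitrogen would help to settle. On these data alone, it is also open how the number would follow the size or nature of the group there, for instance with a longer butyl chain or with a hydroxyethyl group, whose hydroxyl would add oxygen rather than only carbon.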